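Metabolic stability of two aryl-substituted analogues and a third

A few compounds are considered here, and "the series" means these few. Any claim that something is new, unique, unknown or untested is made for them only; others in the source may bear on it.

Measured compounds:
compound 1 `COC(=O)N[C@H](C(=O)N1CCC[C@H]1C(=O)Nc1ccc([C@H]2CC[C@H](c3ccc(NC(=O)[C@@H]4CCCN4C(=O)[C@@H](NC(=O)OC)C(C)C)cc3)N2c2ccc(C(F)(F)F)cc2)cc1)C(C)C` — 58%
compound 2 `COC(=O)N[C@H](C(=O)N1CCC[C@H]1C(=O)Nc1ccc([C@@H]2CC[C@@H](c3ccc(NC(=O)[C@@H]4CCCN4C(=O)[C@@H](NC(=O)OC)C(C)C)cc3)N2c2ccc(F)cc2)cc1)C(C)C` — 49%

In an ADME assay (liver) for metabolic stability, with Liver microsome (Rattus norvegicus) as the target, using microsomes, with a stated time of 30 min (a lower number here means that less of the compound is left, a higher number that more of the compound is left), compound 1 gives 58% and compound 2 gives 49%. The two values lie within the scatter of each other, so compound 2 cannot be set apart from compound 1 on these numbers, even though its figure is the smaller of the two.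

Compound 3 `COC(=O)N[C@H](C(=O)N1CCC[C@H]1C(=O)Nc1ccc([C@@H]2CC[C@@H](c3ccc(NC(=O)[C@@H]4CCCN4C(=O)[C@@H](NC(=O)OC)C(C)C)cc3)N2c2ccc(C(F)(F)F)cc2)cc1)C(C)C` is not yet measured in this assay. It differs from compound 2 by trifluoromethyl in place of fluoro on an aromatic carbon. Going by the values given here, no pair of measured compounds shows this change on its own, so the size of the step is open. Compound 1 carries the same trifluoromethyl group and gives 58%, a number within the scatter of compound 2, so no step beyond the scatter is expected in this assay.

The estimated step from compound 2 to compound 3 is a number 6 percentage points higher from compound 2 to compound 3 (within the scatter). Compound 3 is expected to give about 55%, within 35% to 75%.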

Compound 3, percent of the compound remaining: 56%
The estimate for compound 3 lay 1 percentage points below the measured number; measured number inside the range.
By their numbers in this assay, from the lowest: compounds 2, 3 and 1 (each within the scatter of the next).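

In this assay, trifluoromethyl in place of fluoro, para to a large group, can now be read alone: a number 7 percentage points higher from compound 2 to compound 3 (within the scatter) stays within the scatter, so these two groups are not told apart at this place in the configuration shared by compounds 2 and 3. The inversion of the two saturated ring carbons can also be read alone: a number 2 percentage points lower from compound 1 to compound 3 (within the scatter) likewise gives no separation between the two trifluoromethyl compounds. Compounds 1 and 2 differ in both group and configuration, so neither change could be read from that pair, whereas the second new comparison isolates stereochemistry: the fact that compounds 1 and 3 differ only in the configuration as drawn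

Going by these compounds, whether a different kind of group at this position, such as an amine or a carboxylic acid, would give a step beyond the scatter remains open. Also open is whether the result of inverting these centres carries over to the 4-fluorophenyl compounds, as the compounds shown give that comparison only with trifluoromethyl.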